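The source may report more compounds than this note shows. Statements on the series, on what has been measured and on what is new or still open speak of the compounds shown alone.

Measured in an assay on cells for displacement of a labelled ligand from adenosine receptor A2b (Homo sapiens), read by scintillation counting and radioligand binding, with a stated time of 30 min, tested at 10 uM; a lower number here means less inhibition, a higher number more inhibition at the concentration tested (going by the name of the read-out):

compound 1 `Cn1cnc2c(N3CCCCC3)nc(-c3ccccc3O)nc21`: 30.2%
compound 2 `Cn1cnc2c(N3CCCCC3)nc(-c3ccccc3Cl)nc21`: 32.7%
compound 3 `Cn1cnc2c(N3CCCCC3)nc(-c3cccc(O)c3)nc21`: 29.3%

On the numbers shown, compound 3 does not separate from its two neighbours: the step of a number 0.9 percentage points lower from compound 1 to compound 3 (within the scatter) and the step of a number 3.4 percentage points lower from compound 2 to compound 3 (within the scatter) both sit inside the scatter, as does the step of a number 2.5 percentage points higher from compound 1 to compound 2 (within the scatter) between the other two. Moving the hydroxy from one ring position to another, or exchanging it for chloro, left the read-out essentially where it was.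

Compound 4 `Cn1cnc2c(N3CCCCC3)nc(-c3cccc(O)c3O)nc21` differs from compound 3 by hydroxy in place of hydrogen on an aromatic carbon. Among the measured compounds shown here, no measured pair adds a second hydroxy to a ring that already carries one, so the nearest guides are the three small moves above, each within the scatter. The series has so far shown no change in this assay that is large enough to trust, and the present change is of the same modest kind. The expectation is therefore a step of no more than the scatter, a number 0.7 percentage points higher from compound 3 to compound 4 (within the scatter).

For compound 4 the estimate in this assay is 30%, with a range from 17% to 43%.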

Compound 4, a percentage reported as inhibition, at one concentration (the size of the read-out at that concentration, not a potency): 26%
Beside the measured number, compound 4's estimate is 4 percentage points above it, and the stated range covers the measured number.
By their numbers in this assay, from the lowest: compounds 4, 3, 1 and 2 (each within the scatter of the next).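

In this assay, among the compounds shown here, placing a hydroxy on an aromatic carbon ortho to a hydroxy group, the change from 3-hydroxyphenyl to 2,3-dihydroxyphenyl, gives a number 3.3 percentage points lower from compound 3 to compound 4 (within the scatter) and so yields no step that can be trusted at this position. The comparisons with the other two compounds read the same way, with a number 4.2 percentage points lower from compound 1 to compound 4 (within the scatter) and a number 6.7 percentage points lower from compound 2 to compound 4 (within the scatter) for the two listed changes, so a second hydroxy on this ring joins the earlier hydroxy moves and the exchange for chloro in leaving this assay without a separable difference. No measurement at hand accounts for this flat read-out.

Still open, as far as these compounds go, is whether an amine, a carboxylic acid or a longer chain such as an ethoxy group on this aromatic ring would give a step beyond the scatter in this assay or whether the ring accepts such groups with as little effect as it accepts hydroxy and chloro. Since the read-out is a single-concentration percentage and not a potency, the compounds shown also leave open whether their affinities for the receptor differ in a way that this measure does not resolve.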